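This account rests on a few compounds, and the source may have more. Where it says the series, first, only, none or still open, it means among the compounds named here.

Measured in a functional assay on a cell-free system (plasma, Homo sapiens), with a stated time of 3 min; on this read-out higher numbers stand for weaker inhibition and lower numbers for stronger inhibition:
- compound 1 `O=C(NCc1cc(Cl)ccc1-n1cnnn1)[C@@H]1C[C@H]2C[C@H]2N1C(=O)[C@H](O)c1ccccc1`: 680 nM
- compound 2 `CC(C)(C)C[C@@H](O)C(=O)N1[C@@H]2C[C@@H]2C[C@H]1C(=O)NCc1cc(Cl)ccc1-n1cnnn1`: 520 nM

Compound 2 gives 520 nM and compound 1 gives 680 nM. These two values lie within the scatter of each other, so compound 2 cannot be ranked against compound 1 on these numbers.

The next compound to be read is compound 3 `O=C(NCc1cc(Cl)ccc1-n1cnnn1)[C@@H]1C[C@H]2C[C@H]2N1C(=O)[C@H](O)c1cccc(F)c1`. It carries 3-fluorophenyl in place of neopentyl on a saturated chain carbon bound to a carbonyl carbon and an oxygen on a saturated carbon.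

For the measured compounds named here, one measured step bears on this place: a 1.3-fold lower number from compound 1 to compound 2 (0.12 log units; within the scatter), which put neopentyl in place of phenyl and stayed within the scatter. Going by the values given here, no measured compound yet carries a fluorine on this group, so the effect of that atom is not covered by the data. On the strength of that single small step, no shift beyond the scatter is expected in this assay, and the expected step is a 1.0-fold lower number from compound 2 to compound 3 (0.02 log units; within the scatter). For compound 3 the estimated value is 500 nM, with an expected range of 200 nM to 1200 nM.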

Compound 3, half-maximal inhibitory concentration: 1100 nM
The estimate for compound 3 lay 2.2-fold (0.34 log units) below the measured number, and the stated range covers the measured number.
By their numbers in this assay, from the lowest: compounds 2, 1 and 3 (each within the scatter of the next, the first and the last beyond it).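

In this assay, for the compounds shown here, 3-fluorophenyl in place of neopentyl on a saturated chain carbon bound to a carbonyl carbon and an oxygen on a saturated carbon gives a 2.1-fold higher number from compound 2 to compound 3 (0.33 log units; beyond the scatter) and is the first step at this position to pass the scatter, although only modestly. Fluoro in place of hydrogen on an aromatic carbon gives a 1.6-fold higher number from compound 1 to compound 3 (0.21 log units; within the scatter) and so cannot be separated from the scatter, which means that neopentyl can be ranked against 3-fluorophenyl but not against the unsubstituted phenyl of compound 1, and the fluorine cannot be given an effect of its own. No evidence bearing on the origin of these steps is at hand.

The compounds shown leave open whether a longer chain in place of neopentyl, or an amine or a carboxylic acid carried on this group, would move the number further in either direction. They also leave open whether chloro in place of fluoro on the aromatic ring would give a step beyond the scatter from compound 1, and how far the modest gain with neopentyl extends to other saturated groups.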